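Methyl to Trifluoromethyl on the Pendant Aryl

This account rests on a few compounds, and the source may have more. Where it says the series, first, only, none or still open, it means among the compounds named here.

The series is followed in an ADME assay on HEK-293T cells (Homo sapiens) for cytotoxicity, read by MTT assay, with a stated time of 24 h; on this read-out lower numbers stand for higher toxicity in this test and higher numbers for lower toxicity in this test. Going by the values given here, compound 1 `Cc1cccc(C(=O)n2c(-c3cn(-c4ccccc4)nc3-c3ccc(C(F)(F)F)cc3)nc3ccccc32)c1` gives 154000 nM and compound 2 `O=C(c1ccc(Cl)cc1)n1c(-c2cn(-c3ccccc3)nc2-c2ccc(C(F)(F)F)cc2)nc2ccccc21` gives 181000 nM; the one measured step, a 1.2-fold higher number from compound 1 to compound 2 (0.07 log units; within the scatter), is within the scatter. Compound 3 `Cc1ccc(-c2nn(-c3ccccc3)cc2-c2nc3ccccc3n2C(=O)c2cncc(C)c2)cc1` gives 155000 nM in this assay and stands second highest of the three numbers, nearest compound 1 and furthest from compound 2, both differences within the scatter. On the numbers shown, the three compounds are not separated.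

Compound 4 `Cc1cncc(C(=O)n2c(-c3cn(-c4ccccc4)nc3-c3ccc(C(F)(F)F)cc3)nc3ccccc32)c1` is the next compound. It differs from compound 3 by trifluoromethyl in place of methyl on an aromatic carbon. Among the compounds with values here, no measured step covers this change: the only step on record, from compound 1 to compound 2, concerns the group on the carbonyl carbon and was within the scatter, so it says nothing about the pendant aryl. Compounds 1 and 2 already carry the trifluoromethyl group that enters here, and their numbers sit within the scatter of compound 3. No step beyond the scatter in this assay is therefore expected for compound 4. The expected step of a 1.0-fold higher number from compound 3 to compound 4 (0.01 log units; within the scatter) is within the scatter. The estimate for compound 4 in this assay is 160000 nM, with a range from 80000 nM to 320000 nM.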

Compound 4, half-maximal cytotoxic concentration: 123000 nM
Beside the measured number, compound 4's estimate is 1.3-fold (0.11 log units) above it; low and high end bracket the measured number.
By their numbers in this assay, from the lowest: compounds 4, 1, 3 and 2 (each within the scatter of the next).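

In this assay, going by these compounds alone, the change from 4-methylphenyl to 4-(trifluoromethyl)phenyl, with 5-methylpyridin-3-yl held on the carbonyl carbon, gives a 1.3-fold lower number from compound 3 to compound 4 (0.10 log units; within the scatter) and is the first direct reading of this position, on an aromatic carbon para to a large group. With trifluoromethyl held, the group on the carbonyl carbon now has further readings: 5-methylpyridin-3-yl in place of 4-chlorophenyl gives a 1.5-fold lower number from compound 2 to compound 4 (0.17 log units; within the scatter) and 5-methylpyridin-3-yl in place of 3-methylphenyl gives a 1.3-fold lower number from compound 1 to compound 4 (0.10 log units; within the scatter) so that neither the pendant aryl change nor these carbonyl-side changes separates the four compounds. No supporting measurement bears on these results, so the numbers carry no explanation of their own.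

The compounds shown span only methyl and trifluoromethyl at the pendant aryl position, and only three aryl groups on the carbonyl carbon, so any dependence of this read-out on either place remains undefined. On these data alone, whether an amine or a carboxylic acid on the pendant aryl, or a longer chain on the carbonyl carbon, would produce a step beyond the scatter stays open.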